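A few compounds are considered here, and "the series" means these few. Any claim that something is new, unique, unknown or untested is made for them only; others in the source may bear on it.

Measured compounds:
Compound 1, `CC#C[C@H]1CN(S(=O)(=O)c2ccc(N)nc2)CCN1c1ccc(S(N)(=O)=O)cc1`: 30 mL.min-1.g-1
Compound 2, `CC#C[C@H]1CN(S(=O)(=O)c2ccc(N)nc2)CCN1c1ccc(C(O)(C(F)(F)F)C(F)(F)F)cn1`: 42 mL.min-1.g-1

Both compounds share one core and were run in an ADME assay (liver) for metabolic stability, with Liver microsome (Rattus norvegicus) as the target, using microsomes and NADPH, with a stated time of 30 min; on this read-out lower numbers stand for slow clearance and higher numbers for fast clearance. Compound 1 gives 30 mL.min-1.g-1, the lower of the two numbers, and compound 2 gives 42 mL.min-1.g-1; the gap between them lies within the scatter, so the two numbers cannot be told apart. Among the measured compounds shown here, no pair here differs in only one place, so no single step has been measured.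

The unmeasured compound 3, `CC#C[C@H]1CN(S(=O)(=O)c2ccc(N)nc2)CCN1c1ccc([C@](O)(CO)C(F)(F)F)cc1`, differs from compound 1 as follows: 1,2-dihydroxy-1-(trifluoromethyl)ethyl in place of sulfamoyl on an aromatic carbon. Since nothing on this core has yet been seen to move the read-out beyond the scatter, the expected step is a modest one upward, and the estimate for the step of a 1.5-fold higher number from compound 1 to compound 3 (0.18 log units; within the scatter) reflects that. Compound 3 is expected to give 45 mL.min-1.g-1 in this assay, in the range 20 mL.min-1.g-1 to 100 mL.min-1.g-1.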

Compound 3, intrinsic clearance in microsomes: < 14 mL.min-1.g-1
Compound 3: only a limit was reported; the forecaster's own chance of this, stated with the estimate: 5%; middle value at least 3.2-fold (0.50 log units) away from the limit.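

In this assay, 1,2-dihydroxy-1-(trifluoromethyl)ethyl in place of sulfamoyl on this aromatic carbon, para to a large group, gives an at least 2.1-fold lower number from compound 1 to compound 3 (0.33 log units; beyond the scatter). Among the compounds shown here, this shows that a change at this one position can move intrinsic clearance on the shared core beyond the scatter, which the earlier compounds, with no single step among them, could not show. For compound 3 the reported figure is a limit and not a number, so the step has a floor but no known full size: the limit of < 14 mL.min-1.g-1 in this assay, at which 1 of the 3 values shown sits.

The compounds shown leave open which part of the new group carries the step: the trifluoromethyl, the hydroxyl groups or the defined stereocentre. They also leave open how the opposite stereocentre, a carboxylic acid or a primary amide at this position would read in this assay.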